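This account rests on a few compounds, and the source may have more. Where it says the series, first, only, none or still open, it means among the compounds named here.

Compound 2 `O=c1oc2cccnc2n1CN1CCN(c2ccc(Cl)cc2)CC1` is the starting point. For the measured compounds named here, in a functional assay on the whole organism with Mus musculus as the target (on this read-out lower numbers stand for an effect already at smaller amounts and higher numbers for an effect only at larger amounts of compound), compound 2 gives 10.6 mg/kg, the lower of the two numbers so far, though the gap to its neighbour is within the usual scatter of repeated measurements. That neighbour, compound 1 `O=c1oc2cccnc2n1CCCN1CCN(c2ccccc2)CC1`, carries a phenyl on its piperazine rather than a 4-chlorophenyl and a longer chain to the core; in this assay compound 1 gives 15.5 mg/kg. Compound 3 `CN1CCN(CCn2c(=O)oc3cccnc32)CC1` reaches only the limit of this assay, > 25 mg/kg, so no number is known for it beyond (the limit of > 25 mg/kg in this assay, at which 1 of the 3 values shown sits).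

Compound 4 `O=c1oc2cccnc2n1CN1CCN(c2ccccc2)CC1` keeps everything of compound 2 except one spot: hydrogen in place of chloro on an aromatic carbon. Seen one bond further out, the 4-chlorophenyl becomes a phenyl. Going by the values given here, no measured step of this kind is available, so the expectation rests on the small spread among the numbered compounds. Removing the chloro is expected to move the dose little, most likely upward but within the scatter, the step from compound 2 to compound 4 being estimated at a 1.2-fold higher number from compound 2 to compound 4 (0.09 log units; within the scatter). For compound 4 the expected dose in this assay is 13 mg/kg, with a range from 6.5 mg/kg to 26 mg/kg.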

Compound 4, dose for half-maximal effect: 5.9 mg/kg
Compound 4: the middle estimate sits 2.2-fold (0.34 log units) above what was measured, and the stated range ends above it.
By their numbers in this assay, from the lowest: compounds 4, 2 and 1 (each within the scatter of the next, the first and the last beyond it). At a limit, above all of these: compound 3.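

In this assay, for the compounds shown here, replacing the 4-chlorophenyl with a plain phenyl gives a 1.8-fold lower number from compound 2 to compound 4 (0.25 log units; within the scatter), the first comparison that isolates the chloro, and it shows that the effect in the mouse does not depend measurably on the chloro at this spot. The change also exposes a new single-place comparison, since compound 1 and compound 4 now differ only in the chain to the core, with compound 1 at 15.5 mg/kg and compound 4 at 5.9 mg/kg, a gap beyond the scatter. Nothing measured here bears on why these doses take the values they do.

From the compounds shown here alone, it remains open whether a different group on this aromatic carbon, such as methoxy or trifluoromethyl, would shift the dose beyond the scatter. Also open, going by these compounds, is how a chain of intermediate length, such as an ethyl linker, would behave with the phenyl kept in place.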